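The source may report more compounds than this note shows. Statements on the series, on what has been measured and on what is new or still open speak of the compounds shown alone.

Measured in a functional assay on HCT-116 cells (Homo sapiens) for antiproliferative activity, read by sulforhodamine B assay, with a stated time of 72 h; on this read-out lower numbers stand for stronger inhibition and higher numbers for weaker inhibition:
- compound 1 `Cn1ncc(Cl)c1-c1cc(C(=O)N[C@@H]2CN[C@H](CCN3CCC(O)CC3)C[C@H]2c2ccc(Cl)c(Cl)c2)oc1Cl`: 13700 nM
- compound 2 `Cn1ncc(Cl)c1-c1cc(C(=O)N[C@@H]2CN[C@H](CC(N)=O)C[C@H]2c2ccc(Cl)c(Cl)c2)oc1Cl`: 650 nM
- compound 3 `CNC(=O)C[C@@H]1C[C@@H](c2ccc(F)c(F)c2)[C@H](NC(=O)c2cc(-c3c(Cl)cnn3C)c(Cl)o2)CN1`: 1100 nM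

Compound 2 has the lowest number of the set, but it lies within the scatter of compound 3. Compound 4 `Cn1ncc(Cl)c1-c1cc(C(=O)N[C@@H]2CN[C@H](CC(=O)NC3CC3)C[C@H]2c2ccc(Cl)c(Cl)c2)oc1Cl` has cyclopropyl in place of hydrogen on an amide-type nitrogen.

Among the measured compounds shown here, the only measured step on this chain, a 21-fold lower number from compound 1 to compound 2 (1.32 log units; beyond the scatter), is large but replaces the whole (4-hydroxypiperidin-1-yl)methyl group with carbamoyl, so it bears only loosely on this change. Compound 3 also has a substituted amide nitrogen, but it differs from compound 2 in a second place too.

The expected change is small and within the scatter: a 1.4-fold higher number from compound 2 to compound 4 (0.14 log units; within the scatter), a slight rise at most. For compound 4 the estimated value is 900 nM, with an expected range of 350 nM to 2500 nM.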

Compound 4, half-maximal inhibitory concentration: 740 nM
Estimate against measurement, compound 4: 1.2-fold (0.09 log units) above, within the range that was stated.
By their numbers in this assay, from the lowest: compounds 2, 4 and 3 (each within the scatter of the next); then compound 1.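

In this assay, the amide nitrogen of the carbamoylmethyl chain carries cyclopropyl with the values of compound 2 and compound 4 within the scatter of each other (a 1.1-fold higher number from compound 2 to compound 4 (0.06 log units; within the scatter)), so this nitrogen tolerates a carbon ring in place of the amide hydrogen. The substituted amide also keeps the large gap to the (4-hydroxypiperidin-1-yl)methyl chain (a 19-fold lower number from compound 1 to compound 4 (1.27 log units; beyond the scatter)). No supporting data bear on the reason for either step.

Still open, as far as these compounds go, is whether a benzyl group or a longer chain on this nitrogen would be tolerated. From the compounds shown here alone, replacing the amide with a carboxylic acid or an amine also remains untested in these compounds.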